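Swapping Naphthyl Attachment Points in a Cytotoxicity Series

A few compounds are considered here, and "the series" means these few. Any claim that something is new, unique, unknown or untested is made for them only; others in the source may bear on it.

Compound 1, `CCOC(=O)CCCCCOc1cccc(CN(C(=O)c2ccc(-c3cccc(N(C)C)c3)cc2)C(C)C)c1`: in an ADME assay on HEK293 cells (Homo sapiens) for cytotoxicity, read by CellTiter-Glo and resazurin assay, with a stated time of 72 h (a lower number here means that less compound is needed, a higher number that more compound is needed for the effect), compound 1 gives only a limit, > 26000 nM.
Compound 2, `CCOC(=O)CCCCCOc1cccc(CN(C(=O)c2ccc(-c3cccc4ccccc34)cc2)C(C)C)c1`: in this assay compound 2 gives only a limit, > 26000 nM.

Compound 2 therefore stands at a limit of this assay, a bound rather than a number. Among the measured compounds shown here, the single measured step, a step that the two limits leave unreadable from compound 1 to compound 2, has no readable size because of the limit of > 26000 nM in this assay, at which 2 of the 2 values shown sit. The next compound, compound 3 `CCOC(=O)CCCCCOc1cccc(CN(C(=O)c2ccc(-c3ccc4ccccc4c3)cc2)C(C)C)c1`, differs from compound 2 by naphthalen-2-yl in place of naphthalen-1-yl on an aromatic carbon. For the measured compounds named here, no measured step bears on this change, so no direction can be read from the data. Compound 3 is expected to remain at the same limit, with an expected step that the limit leaves unreadable from compound 2 to compound 3. Compound 3 is thus estimated at 40000 nM, within 20000 nM to 100000 nM.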

Compound 3, half-maximal effective concentration: > 26000 nM
Compound 3 gave a limit, no number; the forecaster's own chance of this, stated with the estimate: 85%; the middle value is on the limit's open side.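

Among the compounds shown here, no step among compound 1, compound 2 and compound 3 can be read in this assay, since each gives only a limit: the limit of > 26000 nM in this assay, at which 3 of the 3 values shown sit. On these data alone, whether naphthalen-2-yl and naphthalen-1-yl differ in this assay remains open, as does the half-maximal effective concentration of all three compounds.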